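Moving a Methyl Group Within the Series of Compound 1

A few compounds are considered here, and "the series" means these few. Any claim that something is new, unique, unknown or untested is made for them only; others in the source may bear on it.

Measured compounds:
Compound 1, `Cc1ccc(-c2nc(CNc3ccc(C(=O)NO)cc3)n(-c3ccccc3)n2)cc1`, gives 62.2%.
Compound 2, `O=C(NO)c1ccc(NCc2nc(-c3ccccc3)nn2-c2ccc(Br)cc2)cc1`, gives 65.9%.
Compound 3, `NC(=O)c1ccc(NCc2nc(-c3ccccc3)nn2-c2ccccc2)cc1`, gives -4.4%.

These three were tested in an assay on Sf9 cells for inhibition of protein deacetylase HDAC6 (Homo sapiens), read by fluorescence, with a stated time of 40 min, tested at 100 nM; on this read-out higher numbers stand for more inhibition at the one concentration tested (going by the name of the read-out) and lower numbers for less inhibition. Compound 1 stands second highest of the three numbers; its nearest neighbour is compound 2, whose value lies within the scatter of that of compound 1, while compound 3 sits far below both, beyond the scatter. No pair of these compounds differs in one place only, so the numbers are read as they stand.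

Compound 4, `Cc1ccccc1-c1nc(CNc2ccc(C(=O)NO)cc2)n(-c2ccccc2)n1`, has not yet been measured in this assay. It differs from compound 1 in one place: 2-methylphenyl in place of 4-methylphenyl on an aromatic carbon. For the measured compounds named here, no measured pair shows the effect of such a change, so the expected step is one within the scatter, with no clear direction. Compound 4 is estimated to give 56%, between 32% and 74%, an expected step of a number 6.2 percentage points lower from compound 1 to compound 4 (within the scatter).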

Compound 4, a percentage reported as inhibition, at one concentration (the size of the read-out at that concentration, not a potency): 53.2%
Compound 4: middle estimate off by 2.8 percentage points, on the high side; the measured number falls inside the stated range.
By their numbers in this assay, from the lowest: compound 3; then compounds 4, 1 and 2 (each within the scatter of the next, the first and the last beyond it).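

Moving the methyl group from 4-methylphenyl to 2-methylphenyl gives the first one-place comparison in this series: in this assay the result is a number 9 percentage points lower from compound 1 to compound 4 (within the scatter) and shows that this shift on the ring attached to the shared core does not separate the two compounds. Nothing available explains this result.

The compounds shown leave open whether a methoxy group, an amine or a carboxylic acid in place of the methyl group would also stay within the scatter of compound 1. They also leave open what a longer chain would do there.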